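Nitro in place of methoxy: working notes

A few compounds are considered here, and "the series" means these few. Any claim that something is new, unique, unknown or untested is made for them only; others in the source may bear on it.

Compound 1 `Cc1cc(Nc2cc(N3CCN(C)CC3)nc(Nc3ccc([N+](=O)[O-])cc3)n2)n[nH]1`: 1090 nM
Compound 2 `COc1cccc(Nc2nc(Nc3cc(C)[nH]n3)cc(N3CCN(C)CC3)n2)c1`: 1080 nM
Compound 3 `Cc1cc(Nc2cc(N3CCN(C)CC3)nc(Nc3cccc([N+](=O)[O-])c3)n2)n[nH]1`: not yet measured

In a functional assay on PC-3 cells (Homo sapiens) for antiproliferative activity, read by CCK-8 assay, with a stated time of 72 h (a lower number here means a stronger inhibitor, a higher number a weaker inhibitor), compound 2 gives 1080 nM, level with compound 1 within the scatter. Compound 3 carries one change from compound 2: nitro in place of methoxy on an aromatic carbon, meta to a large group. Among the measured compounds shown here, the only measured step bearing on this is a 1.0-fold lower number from compound 1 to compound 2 (0.00 log units; within the scatter), where 3-methoxyphenyl replaced 4-nitrophenyl, and it lies within the scatter. No step beyond the scatter is therefore expected in this assay. The expected step is a 1.0-fold higher number from compound 2 to compound 3 (0.01 log units; within the scatter). For compound 3 the estimate is 1100 nM, with an expected range from 500 nM to 2400 nM.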

Compound 3, half-maximal inhibitory concentration: 962 nM
The estimate for compound 3 lay 1.1-fold (0.06 log units) above the measured number, within the range that was stated.
By their numbers in this assay, from the lowest: compounds 3, 2 and 1 (each within the scatter of the next).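

In this assay, nitro in place of methoxy on an aromatic carbon, meta to a large group, gives a 1.1-fold lower number from compound 2 to compound 3 (0.05 log units; within the scatter), so the two groups read as level here. 3-Nitrophenyl in place of 4-nitrophenyl gives a 1.1-fold lower number from compound 1 to compound 3 (0.05 log units; within the scatter), which shows that, across these two placements, where the nitro sits makes no step beyond the scatter. No measurement at hand speaks to the reason for this flatness.

Going by these compounds, whether an amine or a carboxylic acid on this aromatic carbon would step beyond the scatter remains open.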